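The compounds below may be only part of what the source reports. "The series", "measured", "known", "first", "only" and "open" are said of these compounds alone.

Measured in an assay on isolated protein for binding affinity to vitamin D3 receptor (Homo sapiens), with a stated time of 4 h; on this read-out higher numbers stand for weaker inhibition and lower numbers for stronger inhibition:
compound 1 `CCN(CC)CCCNC(=O)c1ccc(C(CC)(CC)c2ccc(OCC(=O)C(C)(C)C)c(C)c2)n1CC` gives 863 nM.
compound 2 `C#CCNC(=O)c1ccc(C(CC)(CC)c2ccc(OCC(O)C(C)(C)C)c(C)c2)n1CC` gives only a limit of the assay, > 10000 nM.
compound 3 `CCn1c(C(=O)NCCN)ccc1C(CC)(CC)c1ccc(OCC(O)C(C)(C)C)c(C)c1` gives 194 nM.

Compound 2 therefore stands at the limit of this assay (the limit of > 10000 nM in this assay, at which 1 of the 3 values shown sits), so only a range is known for it, not a number. Compound 4 `CC[C@@H](C)[C@H](NC(=O)c1ccc(C(CC)(CC)c2ccc(OCC(O)C(C)(C)C)c(C)c2)n1CC)C(=O)O` differs from compound 2 in one place: 1-carboxy-2-methylbutyl in place of propargyl on an amide-type nitrogen. Among the measured compounds shown here, the single measured step at this position, an at least 51-fold lower number from compound 2 to compound 3 (1.71 log units; beyond the scatter), shows that replacing the propargyl carbon chain moved the number from the limit to a measured value. For the measured compounds named here, no measured step covers the 1-carboxy-2-methylbutyl group itself, so the size and direction are uncertain. A moderate step of an at least 3.3-fold lower number from compound 2 to compound 4 (0.52 log units; beyond the scatter) is expected, with a real chance that compound 4 again reaches only the limit. Compound 4 is estimated at 3000 nM, between 400 nM and 15000 nM.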

Compound 4, half-maximal inhibitory concentration: 389 nM
Beside the measured number, compound 4's estimate is 7.7-fold (0.89 log units) above it; the whole stated range lies above it.
By their numbers in this assay, from the lowest: compounds 3 and 4 (each within the scatter of the next); then compound 1. At a limit, above all of these: compound 2.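

Replacing propargyl with 1-carboxy-2-methylbutyl on the amide-type nitrogen gives an at least 25-fold lower number from compound 2 to compound 4 (1.41 log units; beyond the scatter), so a measured value here does not depend on the amine of compound 3. Replacing 2-aminoethyl with the same group gives a 2.0-fold higher number from compound 3 to compound 4 (0.30 log units; within the scatter), so these two very different groups cannot be told apart in this assay. The first step is only a bound, as compound 2 sits at a limit: the limit of > 10000 nM in this assay, at which 1 of the 4 values shown sits.

The compounds shown do not separate the carboxylic acid from the branched chain that carries it. The methyl ester of this group, or a plain 2-methylbutyl chain, would make that separation.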